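The source may report more compounds than this note shows. Statements on the series, on what has been measured and on what is new or still open speak of the compounds shown alone.

Compounds measured so far:
- compound 1 `Cc1ncnc2c1c(-c1cc3ccccc3o1)cn2[C@@H]1O[C@H](CO)[C@@H](O)[C@H]1O`: > 20000 nM
- compound 2 `Cc1nc(N)c2c(-c3cc4ccccc4o3)cn([C@@H]3O[C@H](CO)[C@@H](O)[C@H]3O)c2n1`: 6310 nM
- compound 3 `Cc1ncnc2c1c(-c1ccsc1)cn2[C@@H]1O[C@H](CO)[C@@H](O)[C@H]1O`: 8560 nM

In a functional assay on CEM-DNR-bulk cells (Homo sapiens), read by MTT assay, with a stated time of 72 h (on this read-out lower numbers stand for stronger inhibition and higher numbers for weaker inhibition), compound 1 gives > 20000 nM, which is a limit of the assay and not a number (the limit of > 20000 nM in this assay, at which 1 of the 3 values shown sits). In this assay compound 3 gives 8560 nM, and compound 2 gives 6310 nM; the values of compound 2 and compound 3 lie within the usual scatter of each other, so no order is read between them. Compound 2 carries a different core from compound 1; the difference between the two cores is not broken down here.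

One change is seen in a measured pair: thiophen-3-yl in place of 1-benzofuran-2-yl on an aromatic carbon. It gives an at least 2.3-fold lower number from compound 1 to compound 3 (0.36 log units; beyond the scatter), a step whose true size is open at the upper end since compound 1 only reaches a limit.

The unmeasured compound 4 `Cc1nc(N)c2c(-c3ccsc3)cn([C@@H]3O[C@H](CO)[C@@H](O)[C@H]3O)c2n1` is reached from compound 2 by the same change, (thiophen-3-yl in place of 1-benzofuran-2-yl on an aromatic carbon), at a place described in the same words, so the change is the same. For compound 4 in this assay the step is expected to be a 2.3-fold lower number from compound 2 to compound 4 (0.35 log units; beyond the scatter), resting on the step from compound 1 to compound 3 an at least 2.3-fold lower number from compound 1 to compound 3 (0.36 log units; beyond the scatter) and on the value of compound 2 6310 nM as the starting point. The estimate for compound 4 is 2800 nM, with an expected range from 900 nM to 9000 nM.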

Compound 4, half-maximal inhibitory concentration: > 20000 nM
Compound 4 gave a limit, no number; the forecaster's own chance of this, stated with the estimate: 5%; at least 7.1-fold (0.85 log units) between middle value and limit.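

In this assay, thiophen-3-yl in place of 1-benzofuran-2-yl on the core of compound 2 gives an at least 3.1-fold higher number from compound 2 to compound 4 (0.50 log units; beyond the scatter), so the change does not carry over with the direction it had on the core of compound 1: the same change on two cores in this assay, an at least 2.3-fold lower number (0.36 log units; beyond the scatter) from compound 1 to compound 3 and an at least 3.1-fold higher number (0.50 log units; beyond the scatter) from compound 2 to compound 4, at least 7.4-fold (0.86 log units) apart, beyond the scatter of two such steps. As far as these compounds go, compound 4 gives > 20000 nM, which is a limit of the assay and not a number, so the size of this step stays open at its upper end: the limit of > 20000 nM in this assay, at which 2 of the 4 values shown sit. Among these compounds, the result shows that, for these two cores, the step seen on one core was no guide to the step on the other, but it rests on a single pair of groups and does not show which part of the difference between the cores is responsible, nor how any other group would behave.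

The compounds shown carry only 1-benzofuran-2-yl and thiophen-3-yl on that aromatic carbon, so it remains open whether a phenyl ring, a furan-2-yl group or a short alkyl chain there would follow the direction seen on the core of compound 1 or that seen on the core of compound 2. From the compounds shown here alone, it also remains open whether the opposite directions persist in any read-out other than this assay.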